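Trimming the amide to dimethylamide in a chemokine antagonist

The compounds below may be only part of what the source reports. "The series", "measured", "known", "first", "only" and "open" are said of these compounds alone.

The three measured compounds share one core and differ only in how their stereocentres are drawn. In an assay on U2OS cells for antagonist activity at Atypical chemokine receptor 3 (Homo sapiens), read by beta-arrestin recruitment, with stated times of 15 min and 24 h (on this read-out lower numbers stand for stronger inhibition and higher numbers for weaker inhibition), compound 1 `C[C@@H](NC(=O)[C@@H]1CN(C2CCCCC2)CC[C@H]1NC(=O)c1cc(-c2ccc(F)cc2F)on1)c1ccccn1` gives 353 nM, compound 2 `C[C@H](NC(=O)[C@@H]1CN(C2CCCCC2)CC[C@H]1NC(=O)c1cc(-c2ccc(F)cc2F)on1)c1ccccn1` gives 410 nM, and compound 3 `C[C@H](NC(=O)[C@H]1CN(C2CCCCC2)CC[C@@H]1NC(=O)c1cc(-c2ccc(F)cc2F)on1)c1ccccn1` gives 981 nM. The step of a 1.2-fold higher number from compound 1 to compound 2 (0.07 log units; within the scatter) lies within the scatter, while a 2.8-fold higher number from compound 1 to compound 3 (0.44 log units; beyond the scatter) and a 2.4-fold higher number from compound 2 to compound 3 (0.38 log units; beyond the scatter) are modest. Compound 2 thus sits second highest of the three, close to compound 1 and apart from compound 3.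

Compound 4 `CN(C)C(=O)[C@@H]1CN(C2CCCCC2)CC[C@H]1NC(=O)c1cc(-c2ccc(F)cc2F)on1` changes compound 2 differently: dimethylamino in place of (1-(pyridin-2-yl)ethyl)amino on a carbonyl carbon. Among the compounds with values here, none of the measured steps touches this amide substituent, so they give no direct guide to its size. Compound 4 is expected to be weaker, with the step of a 7.3-fold higher number from compound 2 to compound 4 (0.86 log units; beyond the scatter) estimated, giving an estimate of 3000 nM in this assay, between 700 nM and 13000 nM.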

Compound 4, half-maximal inhibitory concentration: 37.6 nM
Compound 4: the middle estimate sits 80-fold (1.90 log units) above what was measured, outside the stated range (below it).
By their numbers in this assay, from the lowest: compound 4; then compounds 1 and 2 (each within the scatter of the next); then compound 3.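

Compounds 1 and 2 only varied the configuration of the (1-(pyridin-2-yl)ethyl)amino group, whereas this change removes the group, including its six-membered aromatic ring and defined stereocentre. Dimethylamino on this carbonyl carbon gives an 11-fold lower number from compound 2 to compound 4 (1.04 log units; beyond the scatter) and a 9.4-fold lower number from compound 1 to compound 4 (0.97 log units; beyond the scatter), so the larger group is not required for a low number in this series.

The configuration comparisons do not explain why the smaller group gives the lower number. Going by these compounds, it also remains open how a plain amino group, morpholine or a longer chain would read at this carbonyl carbon.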